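From 4-fluorophenyl to phenyl at an assay limit

This account rests on a few compounds, and the source may have more. Where it says the series, first, only, none or still open, it means among the compounds named here.

Measured in an ADME assay on H9c2 cells (Rattus norvegicus) for cytotoxicity, read by MTT assay, with a stated time of 48 h; a higher number here means a weaker inhibitor, a lower number a stronger inhibitor:
Compound 1 `CC(C)(Oc1ccc(Cl)cc1)C(=O)NCCOC(=S)Nc1ccc(F)cc1` gives > 800000 nM
Compound 2 `CC(C)(Oc1ccc(Cl)cc1)C(=O)OCCCOC(=O)CCCCC1CCSS1` gives > 800000 nM

Compound 1 stands at > 800000 nM, a limit of the assay and not a number. Compound 2 gives > 800000 nM, also a limit. No number is therefore available for either, only (the limit of > 800000 nM in this assay, at which 2 of the 2 values shown sit).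

Compound 3 `CC(C)(Oc1ccc(Cl)cc1)C(=O)NCCOC(=S)Nc1ccccc1` follows from compound 1 through hydrogen in place of fluoro on an aromatic carbon, para to a large group. Among the compounds with values here, no measured pair shows this change. In this assay the expected change, in either direction, is none beyond the scatter, and the estimate is a number no higher from compound 1 to compound 3 (the limit leaves the size open). Compound 3 is expected at 800000 nM, with an estimated range from 400000 nM to 1200000 nM.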

Compound 3, half-maximal inhibitory concentration: > 800000 nM
Compound 3 was reported as a limit (the forecaster's own chance of this, stated with the estimate: 85%); the middle value sits exactly at the limit.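

Compound 3 gives > 800000 nM, a limit of the assay and not a number. Within the data shown here, compound 1 also stands at a limit, so no step from compound 1 to compound 3 can be read. The compounds shown leave open whether any change to the shared core would give a number rather than a limit in this assay.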